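Fluoro for Trifluoromethyl on a Limit-Bound Tosylate Triazole

This account rests on a few compounds, and the source may have more. Where it says the series, first, only, none or still open, it means among the compounds named here.

Three compounds have been tested in a functional assay on A549 cells (Homo sapiens) for cytotoxicity, read by MTT assay, with a stated time of 4 days; on this read-out lower numbers stand for stronger inhibition and higher numbers for weaker inhibition:

Compound 1, `Cc1ccc(S(=O)(=O)Oc2ccc3c(c2C)[C@H](Cn2cc(-c4ccc(C(F)(F)F)cc4)nn2)[C@@]24CC(=O)[C@@](C)(CC[C@@H]32)C4)cc1`, gave > 20000 nM, a limit of the assay.
Compound 2, `Cc1c(O)ccc2c1[C@H](Cn1cc(-c3ccc(Cl)cc3)nn1)[C@@]13CC(=O)[C@@](C)(CC[C@@H]21)C3`, gave > 20000 nM, a limit of the assay.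
Compound 3, `C=C1C[C@]23C[C@@]1(O)CC[C@H]2c1ccc(O)c(C)c1[C@@H]3Cn1cc(-c2ccccc2)nn1`, gave > 20000 nM, a limit of the assay.

Compound 1 therefore stands not at a number but at the edge of what the measurement can report, and it shares that position with the other two: the limit of > 20000 nM in this assay, at which 3 of the 3 values shown sit. Every value shown is a limit. Within the data shown here, no step between measured compounds can be computed, and nothing here tells how any change on the shared core moves the read-out.

Compound 4, `Cc1ccc(S(=O)(=O)Oc2ccc3c(c2C)[C@H](Cn2cc(-c4ccc(F)cc4)nn2)[C@@]24CC(=O)[C@@](C)(CC[C@@H]32)C4)cc1`, is the next one to be measured. Compared with compound 1 it carries fluoro in place of trifluoromethyl on an aromatic carbon; the group sits para to a large group on the same six-membered aromatic ring. Among the measured compounds shown here, compound 1 stands at the limit, and no measured step is at hand to lean on. The step is therefore expected to be a step that the limit leaves unreadable from compound 1 to compound 4. Compound 4 would most likely be reported as a limit as well, and is thus estimated at 30000 nM, within a range of 8000 nM to 100000 nM.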

Compound 4, half-maximal inhibitory concentration: > 20000 nM
Compound 4 gave a limit, no number (the forecaster's own chance of this, stated with the estimate: 85%); the middle value lies beyond the limit too.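

Compound 4 stands at a limit of the assay just as compound 1 does, so the change from 4-(trifluoromethyl)phenyl to 4-fluorophenyl gives no step that can be read between compound 1 and compound 4: the limit of > 20000 nM in this assay, at which 4 of the 4 values shown sit.

The compounds shown leave open how any change on the shared core moves the read-out, as none of them yields a number.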